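Swapping the double bond geometry in a prostaglandin-type oxime

This account rests on a few compounds, and the source may have more. Where it says the series, first, only, none or still open, it means among the compounds named here.

Measured so far:
Compound 1, `O=C(O)CCC/C=C1\C[C@H]2C[C@@H](O)[C@H](/C=N/OCc3ccccc3)[C@H]2C1`: 1900 nM
Compound 2, `O=C(O)CCC/C=C1\C[C@H]2C[C@@H](O)[C@H](/C=N\OC(c3ccccc3)c3ccccc3)[C@H]2C1`: 1600 nM

These two compounds share the same bicyclic core carrying an acid-bearing side chain, a hydroxyl and an oxime ether; they differ only in the group on the oxime oxygen. In a functional assay for agonist activity, with Homo sapiens as the target (on this read-out lower numbers stand for stronger inhibition and higher numbers for weaker inhibition), compound 1 gives 1900 nM and compound 2 gives 1600 nM; the two values lie within the scatter of each other, so neither can be called the more potent. Compound 2 carries the lower of the two numbers shown, though only just.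

Compound 3, `O=C(O)CCC/C=C1/C[C@H]2C[C@@H](O)[C@H](/C=N\OC(c3ccccc3)c3ccccc3)[C@H]2C1`, keeps every atom of compound 2. The change is the two compounds have the same atoms and bonds and differ only in configuration as drawn: 1 of 6 stereo elements differ; a double bond is drawn E in compound 2 and Z in compound 3. Within the data shown here, no measured pair here tells how this kind of change plays out, so the direction is open. A shift beyond the scatter seems plausible, and a weakening is expected more often than a gain; the step from compound 2 to compound 3 is estimated at a 2.5-fold higher number from compound 2 to compound 3 (0.40 log units; beyond the scatter). Compound 3 is therefore expected to give about 4000 nM, within a range of 800 nM to 20000 nM.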

Compound 3, half-maximal inhibitory concentration: 23000 nM
Compound 3: the middle estimate sits 5.8-fold (0.76 log units) below what was measured; measured number outside the range, above it.
By their numbers in this assay, from the lowest: compounds 2 and 1 (each within the scatter of the next); then compound 3.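

Redrawing one double bond from E to Z is enough to produce a 14-fold higher number from compound 2 to compound 3 (1.16 log units; beyond the scatter) in this assay, a large step and the only one here that can be read. A newcomer might expect a change that adds or removes no atom to matter little, yet here the shape encoded in this double bond counts for a great deal. The weaker result can be pinned on this double bond alone because nothing else separates the pair: the fact that compounds 2 and 3 differ only in the configuration as drawn

The compounds shown leave open whether the same redrawing would cost as much with the group on the oxime oxygen of compound 1. They also leave open how the Z double bond would fare with a methyl ester in place of the carboxylic acid, or with a longer chain carrying that acid.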